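The compounds below may be only part of what the source reports. "The series", "measured", "known", "first", "only" and "open" are said of these compounds alone.

Measured in an in vitro functional assay on HEK285-7 cells for antagonist activity at prostaglandin D2 receptor 2 (Homo sapiens), read by BRET and beta-arrestin recruitment; on this read-out lower numbers stand for smaller maximal responses and higher numbers for larger maximal responses:
compound 1 `O=C(O)Cc1sc(COc2ccc(Cl)cc2)nc1-c1ccc(Cl)cc1` gives 50%
compound 2 `Nc1nc(-c2ccc(Cl)cc2)c(CC(=O)O)s1` gives 50%
compound 3 `O=C(O)Cc1sc(C(c2ccc(F)cc2)c2ccc(F)cc2)nc1-c1ccnc(N2CCC2)c1` gives 80%

Compound 3 stands highest of the three; compound 1, its nearest, and compound 2, its furthest, both lie below it by margins beyond the usual scatter, and by the same margin. Compound 4 `O=C(O)Cc1sc(C(c2ccc(F)cc2)c2ccc(F)cc2)nc1-c1cn[nH]c1` differs from compound 3 in a single place: 1H-pyrazol-4-yl in place of 2-(azetidin-1-yl)pyridin-4-yl on an aromatic carbon. Within the data shown here, no measured pair isolates this change, so its effect in this assay is unanchored. A step of moderate size downward is expected, a number 15 percentage points lower from compound 3 to compound 4 (beyond the scatter), rather than none. Compound 4 is expected at 65%, between 45% and 85%.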

Compound 4, largest response reached (reported as efficacy), in percent of the reference or control that the assay uses: 80%
Compound 4: the middle estimate sits 15 percentage points below what was measured; low and high end bracket the measured number.
By their numbers in this assay, from the lowest: compounds 1 and 2 (each within the scatter of the next); then compounds 3 and 4 (each within the scatter of the next).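

Swapping 2-(azetidin-1-yl)pyridin-4-yl for 1H-pyrazol-4-yl on the aromatic carbon next to the ring nitrogen gives no change at the digits printed from compound 3 to compound 4 (within the scatter) in this assay. This position therefore accepts a five-membered aromatic ring bearing a hydrogen-bond donor as readily as the larger two-ring group, at least for this pair. No available data account for this outcome.

As far as these compounds go, whether the pyrazole hydrogen matters remains open; a 1-methyl-1H-pyrazol-4-yl group at this carbon would test it. A plain phenyl group there would show whether either ring nitrogen is needed.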